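Nitro for hydroxy on the benzyl ring of compound 2

The source may report more compounds than this note shows. Statements on the series, on what has been measured and on what is new or still open speak of the compounds shown alone.

Going by the values given here, compound 2 `CCOC(=O)N1CCC(N(Cc2ccc(O)cc2)C(=O)N(C)C)CC1`, carrying a 4-hydroxyphenyl group, gives 48600 nM in a functional assay on KB cells (Homo sapiens) for antiproliferative activity, read by MTT assay, with a stated time of 48 h (a lower number here means a stronger inhibitor, a higher number a weaker inhibitor), the highest of the two numbers measured so far; its nearest neighbour is compound 1 `CCOC(=O)N1CCC(N(Cc2cccc([N+](=O)[O-])c2)C(=O)N(C)C)CC1`, which gives 15600 nM. Among the compounds with values here, the only measured step, a 3.1-fold higher number from compound 1 to compound 2 (0.49 log units; beyond the scatter), exchanged a 3-nitrophenyl group for the 4-hydroxyphenyl group. Compound 3 `CCOC(=O)N1CCC(N(Cc2ccc([N+](=O)[O-])cc2)C(=O)N(C)C)CC1` is not yet measured; it differs from compound 2 by nitro in place of hydroxy on an aromatic carbon. Within the data shown here, only the step from compound 1 to compound 2 bears on this change, and it was modest but beyond the scatter; the new step puts a nitro group back onto the ring, now on the aromatic carbon para to a large group. A move back toward the number of compound 1 is therefore expected, a 2.4-fold lower number from compound 2 to compound 3 (0.39 log units; beyond the scatter). For compound 3 the estimate is 20000 nM, with a range from 8000 nM to 50000 nM.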

Compound 3, half-maximal inhibitory concentration: 16400 nM
The estimate for compound 3 lay 1.2-fold (0.09 log units) above the measured number; low and high end bracket the measured number.
By their numbers in this assay, from the lowest: compounds 1 and 3 (each within the scatter of the next); then compound 2.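

In this assay the change of hydroxy to nitro now stands on its own at one ring place, with a 3.0-fold lower number from compound 2 to compound 3 (0.47 log units; beyond the scatter); the earlier step from compound 1 to compound 2 changed the group and its place together. Going from 3-nitrophenyl to 4-nitrophenyl gives a 1.1-fold higher number from compound 1 to compound 3 (0.02 log units; within the scatter), so among these three compounds the number follows the group and not its place on the ring, and no compound here goes against this. Nothing at hand gives a reason for either step.

Going by these compounds, whether an amine or a carboxylic acid on the same aromatic carbon would stay with the nitro compounds or with compound 2 remains open. Also open, on these data alone, is whether hydroxy, like nitro, gives matching numbers at both ring places.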